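Benzyl substitution on the triazole: para-chloro to para-methyl

The source may report more compounds than this note shows. Statements on the series, on what has been measured and on what is new or still open speak of the compounds shown alone.

Measured compounds:
compound 1, `N#Cc1c(Nc2cccc(C(F)(F)F)c2)nc(SCc2cn(Cc3ccccc3Cl)nn2)nc1-c1ccccc1`, 22800 nM in a functional assay on MGC-803 cells (Homo sapiens) for inhibition, read by MTT assay, with a stated time of 72 h; a lower number here means a stronger inhibitor, a higher number a weaker inhibitor
compound 2, `Cc1ccccc1Nc1nc(SCc2cn(Cc3ccccc3Cl)nn2)nc(-c2ccccc2)c1C#N`, 7280 nM
compound 3, `Cc1ccccc1Nc1nc(SCc2cn(Cc3ccc(Cl)cc3)nn2)nc(-c2ccccc2)c1C#N`, > 64000 nM

The value of compound 3 is a limit of the assay, not a number. Compound 3 sits at the limit of > 64000 nM in this assay, at which 1 of the 3 values shown sits, the weakest point recorded in the series. Compound 4, `Cc1ccc(Cn2cc(CSc3nc(Nc4ccccc4C)c(C#N)c(-c4ccccc4)n3)nn2)cc1`, is not yet measured; it carries methyl in place of chloro on an aromatic carbon, that is 4-chlorobenzyl to 4-methylbenzyl.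

Within the data shown here, no measured step covers a chloro-to-methyl exchange. The step of a 3.1-fold lower number from compound 1 to compound 2 (0.50 log units; beyond the scatter) concerns a different part of the molecule. The step of an at least 8.7-fold higher number from compound 2 to compound 3 (0.94 log units; beyond the scatter) shows that moving the chloro on the benzyl from the 2- to the 4-position cost a large amount, so the 4-substituted benzyl in compound 3 is already at the edge of what this assay resolves. A methyl in the same place is not expected to recover that loss; compound 4 is estimated to stay near the limit, with a step that the limit leaves unreadable from compound 3 to compound 4 expected to be none beyond the scatter. The estimate for compound 4 is 80000 nM, within 30000 nM to 200000 nM, most likely reported again only as a limit.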

Compound 4, half-maximal inhibitory concentration: > 64000 nM
Compound 4: no number, only a limit; the forecaster's own chance of this, stated with the estimate: 70%; the middle value does not contradict the limit.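

In this assay compound 4 gives > 64000 nM as a limit of the assay and not a number. Compound 3 and compound 4 therefore share one ceiling, and the step between them cannot be read: the limit of > 64000 nM in this assay, at which 2 of the 4 values shown sit. With an at least 8.7-fold higher number from compound 2 to compound 4 (0.94 log units; beyond the scatter) as the measure, the loss seen with the 4-chlorobenzyl of compound 3 also appears with the 4-methylbenzyl, so in these two compounds it does not depend on the chlorine.

From the compounds shown here alone, how far compound 3 and compound 4 lie past the limit stays unknown, so chloro and methyl cannot be ranked at this place. Also open, going by these compounds, is whether an unsubstituted benzyl, or an amine or a carboxylic acid in place of the methyl, would bring a readable number back.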